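Thiophene replacement of the methoxyphenyl ketone in compound 2

A few compounds are considered here, and "the series" means these few. Any claim that something is new, unique, unknown or untested is made for them only; others in the source may bear on it.

Measured compounds:
compound 1 `COc1ccc(-c2cc3ccccc3nc2/C=C/C(=O)c2ccccc2)cc1` — 6670 nM
compound 2 `COc1ccc(C(=O)/C=C/c2nc3ccccc3cc2-c2ccc(OC)cc2)cc1` — > 10000 nM
compound 3 `COc1ccc(-c2cc3ccccc3nc2/C=C/C(=O)c2ccc(Br)s2)cc1` — 5170 nM

In a functional assay on NCI-H460 cells (Homo sapiens) for antiproliferative activity, read by XTT assay, with a stated time of 72 h (a higher number here means a weaker inhibitor, a lower number a stronger inhibitor), compound 1 gives 6670 nM. In this assay compound 3 gives 5170 nM. For compound 2 only a limit of the assay is known in this assay, > 10000 nM, so compound 2 sits at the edge of what the measurement can report (the limit of > 10000 nM in this assay, at which 1 of the 3 values shown sits), and the steps that reach it carry floors rather than full sizes: an at least 1.4-fold higher number from compound 1 to compound 2 (0.17 log units; that floor lies within the scatter), and an at least 1.9-fold lower number from compound 2 to compound 3 (0.28 log units; that floor lies within the scatter). Between compound 1 and compound 3 the step is a 1.3-fold lower number from compound 1 to compound 3 (0.11 log units; within the scatter).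

Compound 4 `COc1ccc(-c2cc3ccccc3nc2/C=C/C(=O)c2ccsc2)cc1` is not yet measured in this assay. It differs from compound 2 as follows: thiophen-3-yl in place of 4-methoxyphenyl on a carbonyl carbon. For the measured compounds named here, the closest measured step is the one from compound 2 to compound 3, which also removes the 4-methoxyphenyl from the carbonyl carbon and puts in a thiophene, though a different one; it returned a number from a limit. The step from compound 1 to compound 3 shows that a thiophene on the carbonyl carbon in place of phenyl changes little. The expectation is therefore a move of roughly the size an at least 1.6-fold lower number from compound 2 to compound 4 (0.22 log units; that floor lies within the scatter), downward, from the limit of compound 2 back into the measurable range. Compound 4 is estimated at 6000 nM, with a range from 2500 nM to 15000 nM.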

Compound 4, half-maximal inhibitory concentration: 7080 nM
For compound 4 the middle estimate is 1.2-fold (0.07 log units) below the measured one; low and high end bracket the measured number.
By their numbers in this assay, from the lowest: compounds 3, 1 and 4 (each within the scatter of the next). At a limit, above all of these: compound 2.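

In this assay, the replacements on the carbonyl carbon now include an unsubstituted thiophene, and thiophen-3-yl in place of 5-bromothiophen-2-yl gives a 1.4-fold higher number from compound 3 to compound 4 (0.14 log units; within the scatter), while thiophen-3-yl in place of phenyl gives a 1.1-fold higher number from compound 1 to compound 4 (0.03 log units; within the scatter), so phenyl, thiophen-3-yl and 5-bromothiophen-2-yl are not told apart at this position and the bromine carries no readable weight here. The step from the 4-methoxyphenyl ketone reads an at least 1.4-fold lower number from compound 2 to compound 4 (0.14 log units; that floor lies within the scatter), which adds a second thiophene that gives only a floor inside the scatter, so the data do not establish that 4-methoxyphenyl differs from thiophen-3-yl, or from the other groups on this carbon. The full size of that step cannot be read, and compound 2 counts here only as a limit and not as a number: the limit of > 10000 nM in this assay, at which 1 of the 4 values shown sits.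

Open is whether any group on this carbonyl carbon can move the number beyond the scatter, since every readable step among these compounds stays within it. A polar group such as an aminomethyl or a carboxylic acid on the ring at this carbon would test that, as would a longer chain between the carbonyl and the ring.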